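Replacing Diethylcarbamoyl with 3-(Pyrrolidin-1-yl)propyl in Compound 1

The compounds below may be only part of what the source reports. "The series", "measured", "known", "first", "only" and "open" are said of these compounds alone.

Among the measured compounds shown here, in a functional assay on MDA-MB-231 cells (Homo sapiens) for antiproliferative activity, read by MTT assay, with a stated time of 24 h (on this read-out higher numbers stand for an effect only at larger amounts of compound and lower numbers for an effect already at smaller amounts), compound 1 (`CCN(CC)C(=O)CO/N=C(\c1ccc(SC)cc1)c1cccc2ccccc12`) gives 30000 nM, the only actual number available so far. Compound 2 (`CCCCC(CC)CNCCCO/N=C(\c1ccc(OC)cc1)c1cccc2ccccc12`) is reported as > 50000 nM, which is a limit of the assay and not a number. The account now turns to compound 3 (`CSc1ccc(/C(=N\OCCCCN2CCCC2)c2cccc3ccccc23)cc1`), which has not yet been measured. Its structure differs from that of compound 1 by 3-(pyrrolidin-1-yl)propyl in place of diethylcarbamoyl on a saturated chain carbon bound to an oxygen on an unsaturated carbon. For the measured compounds named here, no measured pair of compounds differing in one place is available to size such a change, so no shift beyond the usual scatter is expected in this assay. The estimated change is a 1.2-fold lower number from compound 1 to compound 3 (0.08 log units; within the scatter). Compound 3 is expected at 25000 nM, with an estimated range from 8000 nM to 60000 nM.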

Compound 3, half-maximal effective concentration: > 50000 nM
Compound 3: a limit, no number (the forecaster's own chance of this, stated with the estimate: 30%); at least 2.0-fold (0.30 log units) between middle value and limit.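

In this assay, among the compounds shown here, putting 3-(pyrrolidin-1-yl)propyl in place of diethylcarbamoyl, on a saturated chain carbon bound to an oxygen on an unsaturated carbon, gives the first step that can be read here (an at least 1.6-fold higher number from compound 1 to compound 3 (0.22 log units; that floor lies within the scatter)). Compound 3 gives > 50000 nM, which is a limit of the assay and not a number. The exchange therefore gives no lower number than compound 1, and the step is known only as a floor, with its true size left unresolved: the limit of > 50000 nM in this assay, at which 2 of the 3 values shown sit.

The compounds shown leave open whether a dimethylamine, a piperidine or a morpholine in place of the pyrrolidine would bring a number back within the range of the assay. They also leave open what a carboxylic acid or a shorter chain at this place would give.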